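One More Methoxy on Compound 2

The compounds below may be only part of what the source reports. "The series", "measured", "known", "first", "only" and "open" are said of these compounds alone.

Of the compounds shown here, two built on a shared core have numbers so far. In a functional assay on NCI/ADR-RES cells (Homo sapiens) for inhibition, read by sulforhodamine B assay, with a stated time of 48 h (a higher number here means a weaker inhibitor of growth, a lower number a stronger inhibitor of growth), compound 1 (`CC1(/C=C/c2ccc(F)cc2)C=CC(=O)O1`) gives 25700 nM and compound 2 (`COc1ccc(/C=C/C2(C)C=CC(=O)O2)c(OC)c1`) gives 151000 nM as its reading. Compound 2 therefore stands highest of the two, which makes it the weaker inhibitor of growth in this pair, and the gap between them lies beyond the usual scatter of repeated measurements.

Compound 3 (`COc1ccc(/C=C/C2(C)C=CC(=O)O2)c(OC)c1OC`) keeps everything in compound 2 except for one place. It carries methoxy in place of hydrogen on an aromatic carbon, ortho to two methoxy groups (methoxy in place of hydrogen on an aromatic carbon). Among the compounds with values here, no pair of measured compounds shows what this particular change does, so there is no direct precedent to lean on, and two values are a thin basis for any trend. The cautious expectation is therefore a 1.3-fold lower number from compound 2 to compound 3 (0.10 log units; within the scatter) and no clear shift in either direction beyond the scatter. For compound 3 the expected reading is an estimated 120000 nM (with a range from 40000 nM to 300000 nM) in this assay once it is measured.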

Compound 3, concentration for total growth inhibition: 349000 nM
The estimate for compound 3 lay 2.9-fold (0.46 log units) below the measured number; measured number above the stated range.
By their numbers in this assay, from the lowest: compound 1; then compound 2; then compound 3.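

Within the data shown here, putting methoxy in place of hydrogen on the aromatic carbon ortho to two methoxy groups gives, in (this assay), (a 2.3-fold higher number from compound 2 to compound 3 (0.36 log units; beyond the scatter)), and this is the first change in one place for which a measured effect can be read. The direction is toward weaker inhibition of growth, so at this position the compound with hydrogen is the stronger inhibitor of growth of the two and the added methoxy does not bring any gain. The compounds shown offer no measurement that accounts for this step.

This single pair shows one replacement on one carbon, so it sets no general rule for methoxy groups or for other positions on the aromatic ring. As far as these compounds go, it remains open whether a hydroxyl group, an amine or a chlorine atom on this same carbon would raise the number as methoxy does, lower it or leave it within the scatter, and whether methoxy would have the same effect if either neighbouring methoxy group were absent.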